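Methyl on the Acrylamide Chain: From Compound 3 to Compound 4

A few compounds are considered here, and "the series" means these few. Any claim that something is new, unique, unknown or untested is made for them only; others in the source may bear on it.

Three compounds sharing an amide-bearing aniline attached to a pyrimidine have been tested in a functional assay on HepG2 cells (Homo sapiens) for antiproliferative activity, read by MTT assay, with a stated time of 72 h; on this read-out higher numbers stand for weaker inhibition and lower numbers for stronger inhibition. Compound 1 `CC/C=C\C(=O)Nc1cc(Nc2ncc(C#N)c(-c3cn(C)c4ccccc34)n2)c(OC)cc1N(C)CCN(C)C` gives 1360 nM. Compound 2 `COc1cc(N(C)CCN(C)C)c(NC(=O)/C=C\C(C)C)cc1Nc1ncc(C#N)c(-c2cn(C)c3ccccc23)n1` gives 1810 nM. The difference between them is methyl in place of hydrogen on a saturated chain carbon bound to a double-bonded chain carbon and a saturated chain carbon, and the step it made is a 1.3-fold higher number from compound 1 to compound 2 (0.12 log units; within the scatter). Compound 3 `CC/C=C\C(=O)Nc1cc(Nc2nc(C)cc(-c3cn(C)c4ccccc34)n2)c(OC)cc1N(C)CCN(C)C` gives 2050 nM; it carries a different core from compound 1, and the difference between the two cores is not broken down here.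

Compound 4 `COc1cc(N(C)CCN(C)C)c(NC(=O)/C=C\C(C)C)cc1Nc1nc(C)cc(-c2cn(C)c3ccccc23)n1` has not been measured. It differs from compound 3 by methyl in place of hydrogen on a saturated chain carbon bound to a double-bonded chain carbon and a saturated chain carbon, which is the same change that separates compound 1 from compound 2, made at the same place. Because a 1.3-fold higher number from compound 1 to compound 2 (0.12 log units; within the scatter) lies within the scatter, the step from compound 3 to compound 4 is expected to be small as well, about a 1.3-fold higher number from compound 3 to compound 4 (0.12 log units; within the scatter). On that basis compound 4 is expected to give around 2700 nM in this assay, most likely between 1500 nM and 5000 nM.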

Compound 4, half-maximal inhibitory concentration: 3550 nM
Estimate against measurement, compound 4: 1.3-fold (0.12 log units) below; low and high end bracket the measured number.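

Adding the methyl to the chain, which turns ethyl into isopropyl, gives a 1.7-fold higher number from compound 3 to compound 4 (0.24 log units; within the scatter) in this assay. Set beside the earlier step, the change behaves alike on the two cores as far as this read-out can tell: the same change on two cores in this assay, a 1.3-fold higher number (0.12 log units; within the scatter) from compound 1 to compound 2 and a 1.7-fold higher number (0.24 log units; within the scatter) from compound 3 to compound 4, 1.3-fold (0.11 log units) apart, within the scatter of two such steps. Going by these compounds alone, this shows that, on these two cores, the change leaves the number inside the usual spread of repeated measurements, so a step read on one core was a fair guide to the other; it does not show that the methyl has a real effect or none at all, and with only one pair on each core, it does not show that the same would hold on any further core.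

Going by these compounds, what happens with a larger group at this place, such as tert-butyl or a longer chain, remains open. Also open, on these data alone, is whether a core carrying a carboxylic acid in place of the nitrile of compound 1 would take the change in the same way.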